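Ester swap on a short-lived compound

The compounds below may be only part of what the source reports. "The series", "measured", "known", "first", "only" and "open" are said of these compounds alone.

Measured in an ADME assay on microsomes from liver (Rattus norvegicus) for metabolic stability, read by HPLC, using NADPH, tested at 40 mM, in the presence of a further agent that is not named here; a lower number here means that the compound disappears faster, a higher number that the compound lasts longer:
- compound 1 `CCOC(=O)/C(C#N)=C/c1ccoc1`: < 0.0667 h
- compound 2 `CCOC(=O)/C(C#N)=C/c1cc2ccccc2[nH]1`: < 0.0667 h

Compound 2 stands at < 0.0667 h, which is a limit and not a number. Within the data shown here, the same holds for the only other measured compound: the limit of < 0.0667 h in this assay, at which 2 of the 2 values shown sit. Compound 3 `N#C/C(=C\c1cc2ccccc2[nH]1)C(=O)OC1CCCCC1` carries cyclohexyl in place of ethyl on an oxygen next to a carbonyl group. Among the measured compounds shown here, no measured pair shows a step of this kind, and the read-out gives no number to start from. The expected step of an at least 1.0-fold higher number from compound 2 to compound 3 (0.02 log units; that floor lies within the scatter) lies within the usual scatter, in neither direction. Compound 3 is estimated at 0.07 h, with an expected range of 0.03 h to 0.2 h.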

Compound 3, half-life: 0.417 h
Compound 3: middle estimate off by 6.0-fold (0.78 log units), on the low side, outside the stated range (above it).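

In this assay, cyclohexyl in place of ethyl on an oxygen next to a carbonyl group gives an at least 6.2-fold higher number from compound 2 to compound 3 (0.79 log units; beyond the scatter). Among these compounds, compound 3 is the first compound with a half-life read as a number, so the group at this position can move the read-out clear of the limit. The step is only a floor, because its starting point is not a number: the limit of < 0.0667 h in this assay, at which 2 of the 3 values shown sit.

As far as these compounds go, whether a cyclopentyl ester, a tert-butyl ester or an amide would last as long as cyclohexyl remains open. Also open, from the compounds shown here alone, is whether the same change would carry over to the core of compound 1.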